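The source may hold more compounds than are shown below. What is called first, only, known or untested is meant among the compounds shown, and "the series" means these compounds.

Compounds measured so far, in a functional assay, read by spectrophotometry, with a stated time of 30 min; on this read-out higher numbers stand for weaker inhibition and lower numbers for stronger inhibition:

Compound 1, `Cc1nc2c3ccccc3ccc2c2nc3c(ccc4ccccc43)c(-c3ccccc3Cl)c12`, gives 118 ug/mL.
Compound 2, `Cc1ccc(-c2c3ccc4ccccc4c3nc3c2c(C)nc2c4ccccc4ccc32)cc1`, gives 123 ug/mL.
Compound 3, `Cc1nc2c3ccccc3ccc2c2nc3c(ccc4ccccc43)c(-c3cccc4ccccc34)c12`, gives 111 ug/mL.

Compound 3 stands alongside the other two rather than apart from them: its number sits within the usual scatter of both, with a 1.1-fold lower number from compound 1 to compound 3 (0.03 log units; within the scatter) and a 1.1-fold lower number from compound 2 to compound 3 (0.04 log units; within the scatter). The three measured compounds share one core and differ only in the aryl group carried on a single aromatic carbon, and none of the exchanges at that position has moved the read-out beyond the scatter, including a 1.0-fold higher number from compound 1 to compound 2 (0.02 log units; within the scatter).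

Compound 4, `Cc1nc2c3ccccc3ccc2c2nc3c(ccc4ccccc43)c(-c3cc(O)nc4ccccc34)c12`, continues this series at the same carbon: 2-hydroxyquinolin-4-yl in place of naphthalen-1-yl on an aromatic carbon. For the measured compounds named here, this exchange brings in a group with one hydrogen-bond donor and two hydrogen-bond acceptors, whereas every group swapped among the measured compounds carried none; the measured steps therefore bear on it only in part, and nothing among the measured compounds shows what such a group does here.

All three measured steps at this position were within the scatter, so the step expected for compound 4, a 1.0-fold lower number from compound 3 to compound 4 (0.00 log units; within the scatter), is likewise expected to stay within the scatter, with somewhat wider uncertainty because a 1.1-fold lower number from compound 2 to compound 3 (0.04 log units; within the scatter) and the other steps involved no donor or acceptor. Compound 4 is estimated at 110 ug/mL, within a range from 55 ug/mL to 220 ug/mL.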

Compound 4, half-maximal inhibitory concentration: 92.1 ug/mL
The estimate for compound 4 lay 1.2-fold (0.08 log units) above the measured number, within the range that was stated.
By their numbers in this assay, from the lowest: compounds 4, 3, 1 and 2 (each within the scatter of the next).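

In this assay, for the compounds shown here, 2-hydroxyquinolin-4-yl is the first group at this aromatic carbon to carry a hydrogen-bond donor and hydrogen-bond acceptors, as well as a ring with a hetero atom, and it stays within the scatter of all three earlier aryl groups: a 1.2-fold lower number from compound 3 to compound 4 (0.08 log units; within the scatter) and a 1.3-fold lower number from compound 2 to compound 4 (0.13 log units; within the scatter) and a 1.3-fold lower number from compound 1 to compound 4 (0.11 log units; within the scatter). The earlier compounds had shown only that exchanges among groups with no donor or acceptor left the read-out within the scatter, whereas this series now shows the same for a group that has both, so among these four compounds no exchange at this position has moved the number beyond the scatter. Nothing measured here accounts for why the number stayed within the scatter after this exchange.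

As far as these compounds go, what remains open is whether a group of another kind at this carbon, such as an open-chain amine, a carboxylic acid or a longer alkyl chain in place of the aryl ring, would also stay within the scatter. All four compounds share one core, so they also leave open what an exchange elsewhere on it, such as replacing its methyl group, would do.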